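A few compounds are considered here, and "the series" means these few. Any claim that something is new, unique, unknown or untested is made for them only; others in the source may bear on it.

Compound 2 `C(#Cc1ncnc2c1ncn2Cc1ccccc1)c1ncnc2c1ncn2Cc1ccccc1` stands as the weaker of the two measured compounds in a functional assay on L1210 cells (Mus musculus) for inhibition; a lower number here means a stronger inhibitor, a higher number a weaker inhibitor: compound 2 gives 1800 nM, while compound 1 `C(C#Cc1ncnc2c1ncn2Cc1ccccc1)#Cc1ncnc2c1ncn2Cc1ccccc1` gives 370 nM. The two differ in more than one place, so their values can only be set side by side, and the gap between them lies beyond the usual scatter. Compound 3 `C(#Cc1ncnc2c1ncn2C1CCCCO1)c1ncnc2c1ncn2Cc1ccccc1` has not been measured. It differs from compound 2 in a single place: oxan-2-yl in place of benzyl on an aromatic nitrogen. Among the measured compounds shown here, no measured pair shows what this exchange does in this assay, so the expectation rests on the change alone. A small step in this assay is expected, if anything toward a higher number, though it may well remain within the scatter. That step is estimated as a 1.4-fold higher number from compound 2 to compound 3 (0.14 log units; within the scatter). Compound 3 is therefore expected to give about 2500 nM, within a range from 800 nM to 8000 nM.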

Compound 3, half-maximal inhibitory concentration: 900 nM
For compound 3 the middle estimate is 2.8-fold (0.44 log units) above the measured one; the range from low to high includes it.
By their numbers in this assay, from the lowest: compound 1; then compounds 3 and 2 (each within the scatter of the next).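

Putting oxan-2-yl in place of benzyl on the aromatic nitrogen gives a 2.0-fold lower number from compound 2 to compound 3 (0.30 log units; within the scatter) in this assay. So at this position, a six-membered aromatic ring of carbon only can give way to a non-aromatic ring containing oxygen without a change in the number that stands beyond the scatter, and this benzyl group is not required for inhibition at this level. Nothing available explains why the two groups read so alike in this assay.

As far as these compounds go, compound 3 still carries benzyl on its other half, so the effect of replacing both benzyl groups remains open, as does the effect of the same exchange on compound 1. It is also unknown how this position would respond to a clearly different group, such as an amine or a carboxylic acid.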